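Methoxy in Place of Hydrogen on Three Related Compounds

This account rests on a few compounds, and the source may have more. Where it says the series, first, only, none or still open, it means among the compounds named here.

compound 1 `C=C(C)[C@@H]1CC=C(Cn2cc(COc3ccc(C4NC(=O)NC(C)=C4C(C)=O)cc3)nn2)CC1`: 23300 nM
compound 2 `C=C(C)[C@@H]1CC=C(Cn2cc(COc3cccc(C4NC(=O)NC(C)=C4C(C)=O)c3)nn2)CC1`: 44100 nM
compound 3 `C=C(C)[C@@H]1CC=C(Cn2cc(COc3cc(C4NC(=O)NC(C)=C4C(C)=O)ccc3OC)nn2)CC1`: > 100000 nM

In a functional assay on 786-0 cells (Homo sapiens) for inhibition, read by sulforhodamine B assay, with a stated time of 48 h (on this read-out higher numbers stand for weaker inhibition of growth and lower numbers for stronger inhibition of growth), compound 1 gives 23300 nM and compound 2 gives 44100 nM; these two numbers lie within the usual scatter of each other. The difference between the cores of compound 1 and compound 2 is not broken down here. Compound 3 gives a limit of the assay, > 100000 nM, and not a number. The change from compound 2 to compound 3 is methoxy in place of hydrogen on an aromatic carbon and it gave an at least 2.2-fold higher number from compound 2 to compound 3 (0.35 log units; beyond the scatter); that step rests on (the limit of > 100000 nM in this assay, at which 1 of the 3 values shown sits). Compound 4 `C=C(C)[C@@H]1CC=C(Cn2cc(COc3ccc(C4NC(=O)NC(C)=C4C(C)=O)cc3OC)nn2)CC1` is not yet measured. It differs from compound 1 by methoxy in place of hydrogen on an aromatic carbon, the same kind of change, although here the entering group sits meta to a large group where in compound 3 it sits para to a large group. Because the same kind of change gave an at least 2.2-fold higher number from compound 2 to compound 3 (0.35 log units; beyond the scatter), and compound 1 stands at 23300 nM, compound 4 is expected to give a step of about a 2.6-fold higher number from compound 1 to compound 4 (0.41 log units; beyond the scatter). The estimate for compound 4 is 60000 nM, with a range from 25000 nM to 150000 nM.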

Compound 4, concentration for total growth inhibition: 88100 nM
Compound 4: the middle estimate sits 1.5-fold (0.17 log units) below what was measured; the range from low to high includes it.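

In this assay, methoxy in place of hydrogen on an aromatic carbon also raised the number on the core of compound 1, giving a 3.8-fold higher number from compound 1 to compound 4 (0.58 log units; beyond the scatter), which means weaker inhibition of growth. Set beside the earlier step, the change moves the read-out in the same direction on both cores: the same change on two cores in this assay, an at least 2.2-fold higher number (0.35 log units; beyond the scatter) from compound 2 to compound 3 and a 3.8-fold higher number (0.58 log units; beyond the scatter) from compound 1 to compound 4; the limit leaves it open whether they differ

Compound 3 gives > 100000 nM, which is a limit of the assay and not a number, and the two steps together show a shared direction on these two cores only, neither a shared size nor a rule for any further core.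

The compounds shown leave open whether a hydroxyl group, a fluorine atom or an amine in place of the same hydrogen would raise the number in the same way. They also leave open whether a longer chain, such as ethoxy, would give a step of similar size on either core.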